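Swapping one aryl group on a shared core

A few compounds are considered here, and "the series" means these few. Any claim that something is new, unique, unknown or untested is made for them only; others in the source may bear on it.

Three compounds share one core and differ only in the aromatic group attached to it. Compound 1 `CS(=O)(=O)c1ccc(-c2oc3ccccc3c(=O)c2-c2cc(Cl)cc(Cl)c2)cc1` carries a 3,5-dichlorophenyl, and in an assay on isolated protein for inhibition of prostaglandin G/H synthase 1 (Mus musculus), tested at 10 ug/mL (on this read-out higher numbers stand for more inhibition at the one concentration tested (going by the name of the read-out) and lower numbers for less inhibition), compound 1 gives only a limit of the assay, < 5%. Compound 2 `CS(=O)(=O)c1ccc(-c2oc3ccccc3c(=O)c2-c2ccccc2)cc1` carries a plain phenyl, and in this assay compound 2 also gives only a limit, < 5%. Compound 3 `CS(=O)(=O)c1ccc(-c2oc3ccccc3c(=O)c2-c2cccc(F)c2)cc1` carries a 3-fluorophenyl, and in this assay compound 3 likewise gives only a limit, < 5%. Because every value sits at the same limit (the limit of < 5% in this assay, at which 3 of the 3 values shown sit), the steps a step that the two limits leave unreadable from compound 1 to compound 2, a step that the two limits leave unreadable from compound 1 to compound 3 and a step that the two limits leave unreadable from compound 2 to compound 3 cannot be sized. Compound 4 `COc1ccc(-c2c(-c3ccc(S(C)(=O)=O)cc3)oc3ccccc3c2=O)cc1` differs from compound 3 by 4-methoxyphenyl in place of 3-fluorophenyl on an aromatic carbon. Within the data shown here, no measured step is readable, so no change beyond the scatter is expected. The expected step that the limit leaves unreadable from compound 3 to compound 4 is therefore small. Compound 4 is estimated at 3%, ranging from 0% to 12%.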

Compound 4, a percentage reported as inhibition, at one concentration (the size of the read-out at that concentration, not a potency): < 5%
Compound 4 ended at the assay's limit; the forecaster's own chance of this, stated with the estimate: 80%; the middle value lies beyond the limit too.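

Compound 4 also gives only a limit, < 5%. The steps to it from compound 1, compound 2 and compound 3 therefore cannot be read: the limit of < 5% in this assay, at which 4 of the 4 values shown sit.

Going by these compounds, whether any group on the shared core would give a readable value in this assay stays open.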